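A Second Chloro on the Core and Cell Toxicity

The source may hold more compounds than are shown below. What is called first, only, known or untested is meant among the compounds shown, and "the series" means these compounds.

Two sulfonamides share one fused core. Compound 1 `N#Cc1c(NS(=O)(=O)c2ccccc2[N+](=O)[O-])[n+]([O-])c2ccc(Cl)cc2[n+]1[O-]` carries a 2-nitrophenyl on the sulfonyl sulfur; in an ADME assay on cells (Peritoneal macrophage cell, Mus musculus) for cytotoxicity, read by trypan blue exclusion, with a stated time of 48 h (on this read-out higher numbers stand for lower toxicity in this test and lower numbers for higher toxicity in this test), compound 1 gives 6800 nM. Compound 2 `N#Cc1c(NS(=O)(=O)c2ccc([N+](=O)[O-])cc2)[n+]([O-])c2ccc(Cl)cc2[n+]1[O-]` carries a 4-nitrophenyl instead, and in this assay compound 2 gives 7900 nM. Compound 2 thus holds the highest of the two numbers shown, yet the step of a 1.2-fold higher number from compound 1 to compound 2 (0.07 log units; within the scatter) lies within the scatter, so the two compounds are not told apart here.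

Compound 3 `N#Cc1c(NS(=O)(=O)c2ccc([N+](=O)[O-])cc2)[n+]([O-])c2cc(Cl)c(Cl)cc2[n+]1[O-]` differs from compound 2 by chloro in place of hydrogen on an aromatic carbon. Within the data shown here, no measured step touches the core: the only known step, a 1.2-fold higher number from compound 1 to compound 2 (0.07 log units; within the scatter), alters the aryl on sulfur and offers no guide to a change on the core. A step beyond the scatter in this assay is therefore not expected in either direction. Compound 3 is estimated at 7500 nM, within 3500 nM to 16000 nM, which means an expected step of a 1.1-fold lower number from compound 2 to compound 3 (0.02 log units; within the scatter).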

Compound 3, half-maximal cytotoxic concentration: 89100 nM
Compound 3: the middle estimate sits 12-fold (1.07 log units) below what was measured; measured number outside the range, above it.
By their numbers in this assay, from the lowest: compounds 1 and 2 (each within the scatter of the next); then compound 3.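

In this assay the chloro that enters ortho to a chloro group, on the aromatic carbon of the shared core, brings an 11-fold higher number from compound 2 to compound 3 (1.05 log units; beyond the scatter) and so points to lower toxicity in this test. Among these compounds, the only earlier step of a 1.2-fold higher number from compound 1 to compound 2 (0.07 log units; within the scatter) alters the aryl on sulfur and stays within the scatter, so this position on the core is the first place in the set where a single change separates two compounds. Nothing at hand gives a reason for the size of this step.

From the compounds shown here alone, whether the step belongs to chloro itself or would follow other groups at this carbon stays open, and a fluoro, a methyl, a methoxy or an amine there would speak to that. Going by these compounds, it also remains open whether the same chloro would give a step of like size with the 2-nitrophenyl on sulfur.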